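Trimming the amine on a chalcone-like antiproliferative series

A few compounds are considered here, and "the series" means these few. Any claim that something is new, unique, unknown or untested is made for them only; others in the source may bear on it.

Measured so far in a functional assay on A549 cells (Homo sapiens) for antiproliferative activity, with a stated time of 72 h; a lower number here means a stronger inhibitor, a higher number a weaker inhibitor:
- Compound 1 `COC(=O)CN(C)Cc1c(OC)cc(OC)c(C(=O)/C=C/c2ccccc2Cl)c1O`: 9100 nM
- Compound 2 `CCN(CC)Cc1c(OC)cc(OC)c(C(=O)/C=C/c2ccccc2Cl)c1O`: 3600 nM

Of these two compounds, compound 2 holds the lower number, at 3600 nM in this assay, and is therefore the stronger inhibitor of the pair. The next compound, compound 3 `COc1cc(OC)c(C(=O)/C=C/c2ccccc2Cl)c(O)c1CN(C)C`, has not yet been measured. It departs from compound 2 by one change: dimethylamino in place of diethylamino on a saturated chain carbon bound to an aromatic carbon. In words, dimethylamino stands in place of diethylamino on a saturated chain carbon bound to an aromatic carbon.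

Among the measured compounds shown here, only one measured step bears on this change. It is a 2.5-fold lower number from compound 1 to compound 2 (0.40 log units; beyond the scatter), a modest step that lies beyond the scatter and involves a change on that same kind of carbon. That step does not include dimethylamino, so the data give no direct measure of this replacement. For the measured compounds named here, with a 2.5-fold lower number from compound 1 to compound 2 (0.40 log units; beyond the scatter) as the only guide, a modest step at most is expected, leaning weakly towards a higher number. The expected step is a 1.3-fold higher number from compound 2 to compound 3 (0.12 log units; within the scatter). For compound 3 the estimated value is 4800 nM, with an expected range of 1800 nM to 11000 nM.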

Compound 3, half-maximal inhibitory concentration: 2100 nM
Beside the measured number, compound 3's estimate is 2.3-fold (0.36 log units) above it, within the range that was stated.
By their numbers in this assay, from the lowest: compounds 3 and 2 (each within the scatter of the next); then compound 1.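

In this assay, exchanging diethylamino for dimethylamino on a saturated chain carbon bound to an aromatic carbon gives a 1.7-fold lower number from compound 2 to compound 3 (0.23 log units; within the scatter), so the two amines cannot be told apart at this position. Compound 3 also isolates the methoxycarbonyl as a single change: hydrogen in its place, on a saturated chain carbon bound to an amine nitrogen, gives a 4.3-fold lower number from compound 1 to compound 3 (0.64 log units; beyond the scatter), and together with a 2.5-fold lower number from compound 1 to compound 2 (0.40 log units; beyond the scatter) this sets compound 1 apart from both simple dialkylamines, with each step beyond the scatter. No measurement is available here that explains either step.

The compounds shown leave open how far the amine can be varied at this position, since a longer chain such as dipropylamino or an amine carrying a single methyl could extend the comparison beyond this narrow pair. They also leave open whether the weaker number of compound 1 belongs to the methoxycarbonyl specifically, a question that a carboxylic acid or an amide in its place would bear on directly.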